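A few compounds are considered here, and "the series" means these few. Any claim that something is new, unique, unknown or untested is made for them only; others in the source may bear on it.

Compound 1 `COc1ccc(Cl)cc1C(C)NC(=O)NS(=O)(=O)c1ccccc1`: > 300000 nM
Compound 2 `COc1ccc(F)cc1C(C)NC(=O)NS(=O)(=O)c1ccc(C)cc1`: > 300000 nM

In a functional assay on thoracic aorta (Rattus norvegicus, strain Wistar), with a stated time of 15 min (a lower number here means that less compound is needed, a higher number that more compound is needed for the effect), compound 2 gives > 300000 nM, which is a limit of the assay and not a number. Compound 1 gives > 300000 nM, which is also a limit. The whole picture so far is the limit of > 300000 nM in this assay, at which 2 of the 2 values shown sit, so no true number exists yet and compound 2 cannot be ranked against compound 1.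

Compound 3 `COc1ccc(F)cc1C(C)NC(=O)NS(=O)(=O)c1ccccc1` comes from compound 2 through one small edit: hydrogen in place of methyl on an aromatic carbon, para to a large group, so that 4-methylphenyl becomes phenyl (hydrogen in place of methyl on an aromatic carbon). Among the compounds with values here, no pair of measured compounds shows what this kind of change does in this assay. The expectation therefore rests on compound 2, whose reading of > 300000 nM is a limit. The estimated step of a number no higher from compound 2 to compound 3 (the limit leaves the size open) is expected to stay within the scatter, with no clear direction. For compound 3 the estimate is 300000 nM, with an expected range from 100000 nM to 400000 nM.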

Compound 3, half-maximal effective concentration: > 300000 nM
Compound 3 ended at the assay's limit; the forecaster's own chance of this, stated with the estimate: 75%; the middle value sits exactly at the limit.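

Compound 3 gives > 300000 nM in this assay, which is a limit of the assay and not a number. Within the data shown here, no step from compound 1 or compound 2 to compound 3 can be read, because all three compounds sit at the same limit: the limit of > 300000 nM in this assay, at which 3 of the 3 values shown sit. The compounds shown leave open what either edit does to the true value, and what structure would give a real number in this assay.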